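The source may report more compounds than this note shows. Statements on the series, on what has been measured and on what is new or still open speak of the compounds shown alone.

Compound 1 `Cc1ccc(-c2nc3ccccn3c2Sc2ccccc2)cc1`: > 100000 nM
Compound 2 `Cc1ccc(-c2nc3ccc(C)cn3c2Sc2ccccc2)cc1`: > 100000 nM

In an ADME assay on NIH3T3 cells (Mus musculus) for inhibition, read by MTT assay, with a stated time of 48 h (a higher number here means a weaker inhibitor, a lower number a stronger inhibitor), compound 2 gives > 100000 nM, which is a limit of the assay and not a number. Compound 1 gives > 100000 nM, also a limit. Both compounds therefore sit at the limit of > 100000 nM in this assay, at which 2 of the 2 values shown sit. For the measured compounds named here, the only measured step is a step that the two limits leave unreadable from compound 1 to compound 2, so it offers no size to carry forward.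

Compound 3 `Cc1ccc2nc(-c3ccc(Cl)cc3)c(Sc3ccccc3)n2c1` departs from compound 2 by one small change, chloro in place of methyl on an aromatic carbon, turning 4-methylphenyl into 4-chlorophenyl. With no readable step to go on, no change beyond the usual scatter is expected in this assay, and the result may again be only a limit. The expected step is a number no higher from compound 2 to compound 3 (the limit leaves the size open). The estimate for compound 3 is 100000 nM, with an expected range from 40000 nM to 200000 nM.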

Compound 3, half-maximal inhibitory concentration: > 100000 nM
Compound 3 was reported as a limit; the forecaster's own chance of this, stated with the estimate: 75%; the middle value sits exactly at the limit.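

In this assay no new step can be read from compound 2 to compound 3, since each gives only a limit and not a number: the limit of > 100000 nM in this assay, at which 3 of the 3 values shown sit.

The compounds shown leave open how strongly any of them inhibits, and which change, if any, would bring a readable number.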